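Pentyl in Place of Cyclopropyl: Compound 4 Expected

A few compounds are considered here, and "the series" means these few. Any claim that something is new, unique, unknown or untested is made for them only; others in the source may bear on it.

Compound 1 `COc1nc2ccc(Br)cc2cc1C(c1ccccc1)n1cc(C2CC2)nn1` was tested in an ADME assay on SK-OV-3 cells (Homo sapiens) for cytotoxicity, read by sulforhodamine B assay, with a stated time of 48 h, tested at 10 uM (a higher number here means more inhibition at the concentration tested (going by the name of the read-out), a lower number less inhibition), where compound 1 gives 3.52%. Compound 3 `COc1nc2ccc(Br)cc2cc1C(c1ccccc1)n1cc(CO)nn1` gives 3.23% and compound 2 `CCCCCCCCc1cn(C(c2ccccc2)c2cc3cc(Br)ccc3nc2OC)nn1` gives 2.06%; both lie within the scatter of compound 1, so the three numbers cannot be separated. Compound 4 `CCCCCc1cn(C(c2ccccc2)c2cc3cc(Br)ccc3nc2OC)nn1` differs from compound 1 by pentyl in place of cyclopropyl on an aromatic carbon. Among the compounds with values here, two measured steps bear on this change: a number 1.5 percentage points lower from compound 1 to compound 2 (within the scatter) and a number 0.3 percentage points lower from compound 1 to compound 3 (within the scatter), neither of them beyond the scatter, and the incoming pentyl is a chain, as octyl is. No step beyond the scatter is therefore expected in this assay for compound 4. The step from compound 1 is estimated as a number 0.5 percentage points lower from compound 1 to compound 4 (within the scatter). Compound 4 is expected to give 3%, within -2% to 9%.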

Compound 4, a percentage reported as inhibition, at one concentration (the size of the read-out at that concentration, not a potency): 10.5%
Compound 4: the middle estimate sits 7.5 percentage points below what was measured; measured number outside the range, above it.
By their numbers in this assay, from the lowest: compounds 2, 3, 1 and 4 (each within the scatter of the next).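

In this assay pentyl in place of cyclopropyl gives a number 7 percentage points higher from compound 1 to compound 4 (within the scatter) and so cannot be told apart from cyclopropyl at this position. Within the data shown here, the other two steps read the same way: a number 7.3 percentage points higher from compound 3 to compound 4 (within the scatter) and a number 8.4 percentage points higher from compound 2 to compound 4 (within the scatter) are larger than the earlier steps here, yet pentyl, octyl, hydroxymethyl and cyclopropyl remain inseparable. No measurement is available that bears on these numbers. On these data alone, whether an amine, a carboxylic acid or a chain longer than octyl at this position would give a step beyond the scatter stays open.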